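The source may hold more compounds than are shown below. What is called first, only, known or untested is meant among the compounds shown, and "the series" means these compounds.

Compounds measured in an assay on cells for inhibition of Polyunsaturated fatty acid 5-lipoxygenase (Rattus norvegicus), tested at 5 uM; on this read-out higher numbers stand for more inhibition at the one concentration tested (going by the name of the read-out) and lower numbers for less inhibition:
compound 1 `COc1ccc2[nH]c(C)c(CCCC(=O)N3CCOCC3)c2c1`: 72.9%
compound 2 `CC(C)(C)OC(=O)N1CCN(C(=O)CCCc2c[nH]c3ccccc23)CC1`: 84.1%
compound 3 `CC(C)(C)OC(=O)N1CCN(C(=O)CCCc2cn(Cc3ccccc3)c3ccccc23)CC1`: 38.2%

Compound 3 stands lowest of the three measured compounds. Its nearest neighbour is compound 1, which in this assay gives 72.9% and lies above it beyond the scatter, and the furthest is compound 2, which in this assay gives 84.1%. For the measured compounds named here, the only step between compounds differing in one place is a number 45.9 percentage points lower from compound 2 to compound 3 (beyond the scatter), a large fall brought on by benzyl in place of hydrogen on an aromatic nitrogen.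

Compound 4 `O=C(CCCc1cn(Cc2ccccc2)c2ccccc12)N1CCNCC1` is yet to be measured. It differs from compound 3 as follows: hydrogen in place of tert-butoxycarbonyl on an amine nitrogen in a ring. Going by the values given here, no measured step bears on this change: the benzyl step concerns a different position, and compound 1 and compound 2 differ from each other in more than one place, so their values only show that both sit well above compound 3. With nothing to point in either direction, the step from compound 3 to compound 4 is expected to be a number 0.2 percentage points lower from compound 3 to compound 4 (within the scatter), within the scatter, and compound 4 is estimated to give 38% in this assay, in a range from 15% to 62%.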

Compound 4, a percentage reported as inhibition, at one concentration (the size of the read-out at that concentration, not a potency): 95.4%
Compound 4: middle estimate off by 57.4 percentage points, on the low side, and the stated range ends below it.
By their numbers in this assay, from the lowest: compound 3; then compound 1; then compound 2; then compound 4.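

In this assay, hydrogen in place of tert-butoxycarbonyl on the amine nitrogen in the ring gives a number 57.2 percentage points higher from compound 3 to compound 4 (beyond the scatter), so the group on this nitrogen has a large bearing on the read-out. Compound 3 and compound 4 both carry the benzyl on the aromatic nitrogen, yet compound 4 gives 95.4%, which shows that the benzyl does not by itself hold the number down when this nitrogen bears hydrogen. Nothing in the data given accounts for the size of this step.

From the compounds shown here alone, it remains open whether a small group such as methyl or acetyl on this amine nitrogen would read like hydrogen or like tert-butoxycarbonyl. Going by these compounds, it is also open whether the same exchange would have a similar effect with hydrogen rather than benzyl on the aromatic nitrogen.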